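Swapping a Fluorosulfonyloxy Group for Bromine on a Shared Core

The source may report more compounds than this note shows. Statements on the series, on what has been measured and on what is new or still open speak of the compounds shown alone.

Compound 1 `Cc1ccccc1C(=O)c1ccc2c(c1)C(n1ccccc1=O)=CC(C)(C)O2` and compound 2 `CC1(C)C=C(n2ccccc2=O)c2cc(OS(=O)(=O)F)ccc2O1` share one core and differ only in the group carried on one aromatic carbon. In a functional assay (trachea) with Rattus norvegicus as the target (on this read-out higher numbers stand for higher potency (the scale is a negative logarithm) and lower numbers for lower potency), compound 1 gives 6.25, and compound 2 gives 7.22. Among the compounds with values here, the change of a number 0.97 log units higher from compound 1 to compound 2 (beyond the scatter) is the only measured step, and it leaves compound 2 as the stronger of the two measured compounds.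

Compound 3 `CC1(C)C=C(n2ccccc2=O)c2cc(Br)ccc2O1` has not been measured. It alters the same aromatic carbon once more: bromo in place of (fluorosulfonyl)oxy on an aromatic carbon. Within the data shown here, the single measured step shows that this aromatic carbon responds clearly to the group placed on it, but that step compared (fluorosulfonyl)oxy with (2-methylphenyl)carbonyl, not with bromo, so it gives no direction for the new change. A step of either sign is therefore possible, and a moderate drop from the highest value seems the more cautious expectation. For compound 3 in this assay the estimate is 6.8, lying between 6 and 7.6. This corresponds to an expected step of a number 0.42 log units lower from compound 2 to compound 3 (beyond the scatter).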

Compound 3, logarithm of the reciprocal of the active concentration, log(1/C): 7.53
The estimate for compound 3 lay 0.73 log units below the measured number, and the stated range covers the measured number.
By their numbers in this assay, from the lowest: compound 1; then compound 2; then compound 3.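

In this assay, bromo in place of (fluorosulfonyl)oxy gives a number 0.31 log units higher from compound 2 to compound 3 (beyond the scatter), so a modest further gain is still available at this aromatic carbon after the first rise. Measured against the (2-methylphenyl)carbonyl group, bromo gives a number 1.28 log units higher from compound 1 to compound 3 (beyond the scatter), a large step that makes compound 3 the most potent of the three, with both of its steps beyond the scatter. Bromo brings 1 heavy atom and 0 hydrogen-bond acceptors where (fluorosulfonyl)oxy has 5 heavy atoms and 3 hydrogen-bond acceptors, so at this position neither the larger group nor its acceptors are needed to reach the highest number seen here.

The three compounds cannot show whether bromine itself matters or whether other small groups on this carbon, such as chlorine, methyl, methoxy or an amine, would do as well or better. Nothing available explains why the numbers fall in this order.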